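The source may report more compounds than this note shows. Statements on the series, on what has been measured and on what is new or still open speak of the compounds shown alone.

In a physicochemical assay for lipophilicity (a lower number here means a more polar compound, a higher number a more lipophilic compound), compound 1 (`CC(C)N(C1=NCCN1)c1c(Br)cccc1Br`) gives -0.82, compound 2 (`CC(C)CCN(C1=NCCN1)c1c(Br)cccc1Br`) gives 0.16 and compound 3 (`C=C(C)CCN(C1=NCCN1)c1c(Br)cccc1Br`) gives 0.02. These numbers place compound 3 level with compound 2 and well clear of compound 1. Compound 4 (`Brc1cccc(Br)c1N(C1=NCCN1)C1CCCC1`) has cyclopentyl in place of 3-methylbut-3-en-1-yl on a nitrogen on an aromatic ring. The nearest evidence is the change of group at that nitrogen, which gave a number 0.98 log units higher from compound 1 to compound 2 (beyond the scatter) and a number 0.84 log units higher from compound 1 to compound 3 (beyond the scatter), while the change within the chain gave only a number 0.14 log units lower from compound 2 to compound 3 (within the scatter). Among the measured compounds shown here, no measured compound tests a ring there, so the guide is weak. Only a small fall is expected, a number 0.17 log units lower from compound 3 to compound 4 (within the scatter). Compound 4 is estimated at -0.15, with an expected range from -0.55 to 0.25.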

Compound 4, distribution coefficient: -0.29
Compound 4: the middle estimate sits 0.14 log units above what was measured, within the range that was stated.
By their numbers in this assay, from the lowest: compound 1; then compound 4; then compounds 3 and 2 (each within the scatter of the next).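

With the same atoms joined differently, cyclopentyl in place of 3-methylbut-3-en-1-yl on the nitrogen gives a number 0.31 log units lower from compound 3 to compound 4 (beyond the scatter) in this assay, so at this position the arrangement of the carbons counts, not only their number. Against isopentyl the ring gives a number 0.45 log units lower from compound 2 to compound 4 (beyond the scatter), and against isopropyl it gives a number 0.53 log units higher from compound 1 to compound 4 (beyond the scatter), which places compound 4 between the isopropyl compound and both longer chains. Nothing measured here accounts for this order. The compounds shown leave open whether cyclopropyl or cyclohexyl would fall in the same place as cyclopentyl, and whether a ring holding an oxygen, such as tetrahydropyranyl, would keep this order.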